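Working notes: bromo for chloro, compound 1 to compound 3

This account rests on a few compounds, and the source may have more. Where it says the series, first, only, none or still open, it means among the compounds named here.

Measured compounds:
- compound 1 `NC(=O)c1c(NC(=O)c2ccccc2Cl)sc2c1CCN(C(=S)Nc1ccccc1C(F)(F)F)C2`: 26700 nM
- compound 2 `NC(=O)c1c(NC(=O)c2ccccc2Cl)sc2c1CCN(C(=S)Nc1c(Cl)cccc1Cl)C2`: 26500 nM

In a functional assay on HeLa cells (Homo sapiens) for antiproliferative activity, with a stated time of 24 h (on this read-out lower numbers stand for stronger inhibition and higher numbers for weaker inhibition), compound 1 gives 26700 nM, the highest of the two numbers shown, with compound 2 as its nearest neighbour. In this assay, for the measured compounds named here, compound 2 gives 26500 nM; the only measured step is a 1.0-fold lower number from compound 1 to compound 2 (0.00 log units; within the scatter), a change on the nitrogen of the other aryl group.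

Compound 3 `NC(=O)c1c(NC(=O)c2ccccc2Br)sc2c1CCN(C(=S)Nc1ccccc1C(F)(F)F)C2` differs from compound 1 by bromo in place of chloro on an aromatic carbon. Going by the values given here, no measured step touches this position. Among the compounds with values here, the one step on hand, a 1.0-fold lower number from compound 1 to compound 2 (0.00 log units; within the scatter), changes a different ring and gives no direction for a halogen swap on the 2-chlorophenyl carbonyl side; it only shows that the two measured compounds sit together.

With nothing bearing directly on it, the expectation for compound 3 in this assay is a step of about a 1.0-fold lower number from compound 1 to compound 3 (0.01 log units; within the scatter), none beyond the scatter. Compound 3 is therefore estimated at 26000 nM, in the range 9000 nM to 70000 nM.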

Compound 3, half-maximal inhibitory concentration: 39600 nM
The estimate for compound 3 lay 1.5-fold (0.18 log units) below the measured number; measured number inside the range.
By their numbers in this assay, from the lowest: compounds 2, 1 and 3 (each within the scatter of the next).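

The halogen on the (2-chlorophenyl)carbonyl group now has a measured step of its own, which the earlier change on the other aryl group could not supply: in this assay, bromo in place of chloro on this aromatic carbon, ortho to a large group, gives a 1.5-fold higher number from compound 1 to compound 3 (0.17 log units; within the scatter) and stays inside the usual scatter. For this one halogen swap, the position therefore shows no difference that can be told from repeat-measurement noise, though a single pair says little about the position as a whole. No supporting data offer an explanation for this step.

From the compounds shown here alone, whether fluoro, methoxy or an amine at this aromatic carbon would move the number beyond the scatter remains open. So does whether bromo behaves alike when paired with the 2,6-dichlorophenyl group of compound 2.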